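The source may hold more compounds than are shown below. What is called first, only, known or untested is meant among the compounds shown, and "the series" means these compounds.

Measured so far:
Compound 1 `COc1cc2ncnc(-n3nc(-c4ccccn4)nc3N)c2cc1[N+](=O)[O-]` — in an assay on MCF7 cells for inhibition of Serine-protein kinase ATM (Homo sapiens), read by immunofluorescence, with a stated time of 1 h (a lower number here means a stronger inhibitor, a higher number a weaker inhibitor), compound 1 gives 31100 nM.
Compound 2 `CCN(CC)C(=O)COc1cc2c(-n3nc(-c4ccccn4)nc3N)ncnc2cc1OC` — in this assay compound 2 gives 5300 nM.

Within the data shown here, compound 2 holds the lowest of the two numbers in this assay; its nearest neighbour is compound 1, and the distance between them is the single step of a 5.9-fold lower number from compound 1 to compound 2 (0.77 log units; beyond the scatter). That step is the only one in hand and it concerns a change at the aromatic carbon itself, nitro giving way to (diethylcarbamoyl)methoxy.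

Compound 3 `COc1cc2ncnc(-n3nc(-c4ccccn4)nc3N)c2cc1OCCCNC(=O)OC(C)(C)C` keeps the core of compound 2 and the oxygen on the aromatic ring, and differs further out along the chain: 2-((tert-butoxycarbonyl)amino)ethyl in place of diethylcarbamoyl on a saturated chain carbon bound to an oxygen on an aromatic ring. Among the measured compounds shown here, the one measured step therefore bears on it only loosely, since in compound 3 the link to the ring stays as in compound 2 and only the tail beyond the chain carbon is exchanged. Nothing in hand shows how such a tail exchange moves the numbers in this assay, so no step beyond the scatter is expected in either direction. For compound 3 the estimate in this assay is 5000 nM, within 1500 nM to 17000 nM. This expectation amounts to a step of a 1.1-fold lower number from compound 2 to compound 3 (0.03 log units; within the scatter).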

Compound 3, half-maximal inhibitory concentration: 900 nM
Beside the measured number, compound 3's estimate is 5.6-fold (0.74 log units) above it, outside the stated range (below it).
By their numbers in this assay, from the lowest: compound 3; then compound 2; then compound 1.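

Among these compounds, the earlier pair showed only that the group on the aromatic carbon can shift the number. Compound 3 shows that with the oxygen on the ring kept, changing the tail alone still moves the result in this assay beyond the scatter: replacing diethylcarbamoyl with 2-((tert-butoxycarbonyl)amino)ethyl on a saturated chain carbon bound to an oxygen on an aromatic ring gives a 5.9-fold lower number from compound 2 to compound 3 (0.77 log units; beyond the scatter) and so the part of the substituent far from the ring counts here too. Taken from the nitro compound, 3-((tert-butoxycarbonyl)amino)propoxy in place of nitro on an aromatic carbon gives a 35-fold lower number from compound 1 to compound 3 (1.54 log units; beyond the scatter) and this is the only large step in hand, although no measurement available here explains it.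

The exchange alters the chain and its end group together, so the compounds shown do not separate the contribution of the 3-((tert-butoxycarbonyl)amino)propoxy chain from that of the tert-butoxycarbonyl group. A free primary amine or a carboxylic acid at the end of that chain, or a longer chain carrying the same end group, would bear on that question.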